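A few compounds are considered here, and "the series" means these few. Any claim that something is new, unique, unknown or untested is made for them only; others in the source may bear on it.

Measured so far in a functional assay on PC-3 cells (Homo sapiens) for cytotoxicity, read by MTT assay, with a stated time of 72 h; a lower number here means a stronger inhibitor, a higher number a weaker inhibitor:
compound 1 `COc1ccc(Nc2cc(C)nc(SCc3nc4ccccc4[nH]3)n2)cc1`: compound 1 gives 67400 nM.
compound 2 `Cc1cc(NCCO)nc(SCc2nc3ccccc3[nH]2)n1`: compound 2 gives > 100000 nM, which is a limit of the assay and not a number.

Compound 2 therefore stands at the weak end of the two results shown; its value is the assay limit noted in the limit of > 100000 nM in this assay, at which 1 of the 2 values shown sits, so its true number is unknown. Among the measured compounds shown here, the only measured step, an at least 1.4-fold higher number from compound 1 to compound 2 (0.17 log units; that floor lies within the scatter), runs toward weaker inhibition, and its floor lies within the scatter, so the size of that step is only partly defined.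

Compound 3 `Cc1cc(NNC(N)=S)nc(SCc2nc3ccccc3[nH]2)n1` differs from compound 2 by a group of 4 heavy atoms (1 carbon, 2 nitrogen, 1 sulfur; no ring) in place of a group of 3 heavy atoms (2 carbon, 1 oxygen; no ring), on a nitrogen on an aromatic ring. For the measured compounds named here, no measured step swaps one small non-ring group for another on a nitrogen on an aromatic ring; the only step at that position is the one from compound 1 to compound 2, where loss of the 4-methoxyphenyl gave a weaker number. Compound 3 keeps a small non-ring substituent there, so no shift beyond the scatter is expected, and a limit is again plausible. The expected step, a number no higher from compound 2 to compound 3 (the limit leaves the size open), is set near zero. Compound 3 is estimated at 100000 nM, within 30000 nM to 300000 nM.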

Compound 3, half-maximal inhibitory concentration: > 100000 nM
Compound 3 ended at the assay's limit (the forecaster's own chance of this, stated with the estimate: 55%); the middle value lies on the limit itself.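

In this assay compound 3 gives > 100000 nM, which is a limit of the assay and not a number. Replacing the 4-methoxyphenyl of compound 1 with a different small non-ring group gives an at least 1.4-fold higher number from compound 1 to compound 3 (0.17 log units; that floor lies within the scatter), so this change is also only partly defined in size and its floor does not clear the scatter. The step between the two non-ring groups cannot be read, but this position on a nitrogen on an aromatic ring now carries two different non-ring groups, one with sulfur and one with oxygen, that both end at the same limit: the limit of > 100000 nM in this assay, at which 2 of the 3 values shown sit.

The compounds shown leave open whether the aromatic ring or the methoxy group of the 4-methoxyphenyl is what separates compound 1 from that limit, and how far the true numbers of compound 2 and compound 3 lie beyond it. A plain phenyl, a benzyl group or a longer alkyl chain on the same nitrogen would bear on that question.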